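Swapping the aryl group on the saturated ring carbon of compound 1

The compounds below may be only part of what the source reports. "The series", "measured", "known", "first", "only" and "open" are said of these compounds alone.

Measured compounds:
Compound 1, `COc1cc(C2=NN(C(C)=O)C(c3c(Cl)cccc3Cl)O2)cc(OC)c1OC`: 15.9%
Compound 2, `COc1cc(C(=O)N/N=C/c2cccc(F)c2)cc(OC)c1OC`: 44.8%

Of the compounds shown here, two have been tested in a functional assay on BGC-823 cells (Homo sapiens) for antiproliferative activity, read by MTT assay, tested at 5 uM; on this read-out lower numbers stand for a weaker effect and higher numbers for a stronger effect at the one concentration tested. Compound 1 shows 15.9%, and compound 2 shows 44.8%. Of these two numbers, compound 1 stands lowest; the gap to compound 2 lies beyond the usual scatter of the measurement. Going by the values given here, compound 2 is built on a different core, so the two values show only that compound 2 is the stronger of the pair and nothing about any single change.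

Compound 3, `COc1cc(C2=NN(C(C)=O)C(c3ccccc3F)O2)cc(OC)c1OC`, keeps the core of compound 1 and differs from it in one place: 2-fluorophenyl in place of 2,6-dichlorophenyl on a saturated ring carbon. Among the compounds with values here, no measured pair in the set shares this change, so its effect in this assay is not known from the data. Compound 3 is therefore expected to stay close to compound 1, with the step of a number 6.1 percentage points higher from compound 1 to compound 3 (within the scatter) estimated to lie within or only slightly beyond the scatter. The estimated inhibition for compound 3 is 22%, with a range from 8% to 40%.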

Compound 3, a percentage reported as inhibition, at one concentration (the size of the read-out at that concentration, not a potency): 32.8%
Estimate against measurement, compound 3: 10.8 percentage points below; low and high end bracket the measured number.
By their numbers in this assay, from the lowest: compound 1; then compound 3; then compound 2.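

In this assay, going by these compounds alone, placing 2-fluorophenyl in place of 2,6-dichlorophenyl on the saturated ring carbon gives a number 16.9 percentage points higher from compound 1 to compound 3 (beyond the scatter), the first step in the set that can be read for a single change, and it shows that the aryl group at this position of the shared core can move the read-out by more than the usual scatter. Within the data shown here, the change has more than one part, however: both chlorines leave and one fluorine enters, and the group falls from 8 heavy atoms to 7, so the single step cannot tell whether the loss of chlorine, the gain of fluorine or the two together account for the rise. No measurement in hand gives any reason for the difference.

What the compounds shown leave open is how a plain phenyl, a 2-chlorophenyl or a 2,6-difluorophenyl would read at this position, which would split the step into its parts. Also open, from the compounds shown here alone, is whether an aryl group carrying a dimethylamino group or a carboxylic acid would be tolerated on this carbon, and whether the acetyl group on the ring nitrogen matters to the read-out.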